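A few compounds are considered here, and "the series" means these few. Any claim that something is new, unique, unknown or untested is made for them only; others in the source may bear on it.

Compound 3, `O=C(Nc1ccncc1)c1c(O)c2cccnc2n(-c2ccccc2)c1=O`, in a functional assay on the whole organism for inhibition, with Rattus norvegicus as the target, read by cytopathic effect and paw edema, at a dose of 100 mg/kg by the oral route (a lower number here means less inhibition, a higher number more inhibition at the dose given (going by the name of the read-out)), gives 24.3%. Two other compounds share its core. Compound 1, `CNC(=O)c1c(O)c2cccnc2n(-c2ccccc2)c1=O`, gives 21%, and compound 2, `CN(C)CCNC(=O)c1c(O)c2cccnc2n(-c2ccccc2)c1=O`, gives 18.4%. Compound 3 carries the highest of these three numbers, yet the step of a number 3.3 percentage points higher from compound 1 to compound 3 (within the scatter) and the step of a number 5.9 percentage points higher from compound 2 to compound 3 (within the scatter) both fall inside the scatter of repeated runs, as does the step of a number 2.6 percentage points lower from compound 1 to compound 2 (within the scatter), so the three numbers cannot be told apart with confidence.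

Compound 4, `COc1ccc(NC(=O)c2c(O)c3cccnc3n(-c3ccccc3)c2=O)cn1`, differs from compound 3 in one place: 6-methoxypyridin-3-yl in place of pyridin-4-yl on an amide-type nitrogen. Among the measured compounds shown here, the steps that bear on this change are the ones that swap the group on the amide-type nitrogen, from compound 1 to compound 3 and from compound 2 to compound 3, and neither left the scatter. A change of the same kind is therefore expected to give no step beyond the scatter in this assay, so compound 4 is estimated at 23%, between 10% and 36%, which means an expected step of a number 1.3 percentage points lower from compound 3 to compound 4 (within the scatter).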

Compound 4, a percentage reported as inhibition, in the whole organism at one dose (the size of the read-out at that dose, not a potency): -10.2%
Estimate against measurement, compound 4: 33.2 percentage points above; measured number outside the range, below it.
By their numbers in this assay, from the lowest: compound 4; then compounds 2, 1 and 3 (each within the scatter of the next).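

In this assay, the group on the amide-type nitrogen can shift the number after all: the earlier swaps there stayed within the scatter, but 6-methoxypyridin-3-yl gives a number 34.5 percentage points lower from compound 3 to compound 4 (beyond the scatter), a number 28.6 percentage points lower from compound 2 to compound 4 (beyond the scatter) and a number 31.2 percentage points lower from compound 1 to compound 4 (beyond the scatter). A six-membered aromatic ring with 1 hetero atom on that nitrogen does not settle the outcome by itself, since compound 3 and compound 4 both carry one and still lie far apart. Nothing measured here tells what lies behind this drop.

The compounds shown cannot separate the methoxy group from the place where the ring is attached to the amide-type nitrogen. Going by these compounds, a plain pyridin-3-yl would help to separate the two, and it remains open whether it would fall near compound 3 or near compound 4.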